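Compound 3 to compound 4: swapping the thiophene group

The source may report more compounds than this note shows. Statements on the series, on what has been measured and on what is new or still open speak of the compounds shown alone.

Values so far in a functional assay on MCF7 cells (Homo sapiens) for cytotoxicity, read by ELISA, with a stated time of 4 days (on this read-out higher numbers stand for weaker inhibition and lower numbers for stronger inhibition), are as follows.
- compound 1 `Cc1ccsc1-c1cc(-c2ccoc2)cc(-c2ccc(Cl)cc2)n1` at 20300 nM
- compound 2 `Clc1ccc(-c2cc(-c3ccco3)cc(-c3ccc(Cl)s3)n2)cc1` at 1520 nM
- compound 3 `Cc1ccsc1-c1cc(-c2ccc(Cl)o2)cc(-c2ccc(Cl)cc2)n1` at 15300 nM

Compound 3 lies within the scatter of compound 1 and well above compound 2 on these numbers. Compound 4 `Clc1ccc(-c2cc(-c3ccc(Cl)o3)cc(-c3ccc(Cl)s3)n2)cc1` differs from compound 3 by 5-chlorothiophen-2-yl in place of 3-methylthiophen-2-yl on an aromatic carbon with 5-chlorothiophen-2-yl in place of 3-methylthiophen-2-yl next to the ring nitrogen. Within the data shown here, the only measured step, a 1.3-fold lower number from compound 1 to compound 3 (0.12 log units; within the scatter), concerns the introduction of 5-chlorofuran-2-yl in place of furan-3-yl and stays within the scatter. Among the measured compounds shown here, no measured step covers the thiophene swap itself. Compound 2 shares 5-chlorothiophen-2-yl with compound 4 and lacks only the chlorine of the 5-chlorofuran-2-yl group, so compound 4 is expected to fall near compound 2 at 1520 nM rather than near compound 3. The expected move in this assay is downward and beyond the scatter, estimated as a 6.1-fold lower number from compound 3 to compound 4 (0.79 log units; beyond the scatter) on this evidence. The estimate for compound 4 is 2500 nM with an expected range from 800 nM to 8000 nM in this read-out.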

Compound 4, half-maximal inhibitory concentration: 12600 nM
For compound 4 the middle estimate is 5.0-fold (0.70 log units) below the measured one; measured number above the stated range.
By their numbers in this assay, from the lowest: compound 2; then compounds 4, 3 and 1 (each within the scatter of the next).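

In this assay, 5-chlorothiophen-2-yl in place of 3-methylthiophen-2-yl next to the ring nitrogen gives a 1.2-fold lower number from compound 3 to compound 4 (0.08 log units; within the scatter), so with a 5-chlorofuran-2-yl group on the core these two thiophene groups cannot be told apart at this position. The chlorine of the 5-chlorofuran-2-yl group marks the larger step, an 8.3-fold higher number from compound 2 to compound 4 (0.92 log units; beyond the scatter), so 5-chlorothiophen-2-yl at this position does not by itself go with a number as low as that of compound 2. No measured evidence on the compounds bears on this result.

Going by these compounds, whether the two thiophene groups also stay indistinguishable with furan-2-yl in place of 5-chlorofuran-2-yl remains open. On these data alone, how an amine or a carboxylic acid would read at the position next to the ring nitrogen is also open.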